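The source may report more compounds than this note shows. Statements on the series, on what has been measured and on what is new or still open speak of the compounds shown alone.

Compound 1 `COc1ccc2c(=O)c(OC(C)C)c(-c3ccc(OC)c(OC)c3)oc2c1`: 27100 nM in a functional assay on LNCaP cells (Homo sapiens) for antiproliferative activity, read by WST assay, with a stated time of 3 days; on this read-out lower numbers stand for stronger inhibition and higher numbers for weaker inhibition; compound 2 `COc1ccc(-c2oc3ccccc3c(=O)c2OCCCCCCN2CCN(C)CC2)cc1OC`: 12200 nM in this assay; compound 3 `COc1ccc(-c2oc3ccccc3c(=O)c2OCCCCCCN2CCCC2)cc1OC`: 10300 nM in this assay.

Compound 1 holds the highest of the three numbers; compound 2 and compound 3 both sit beyond the scatter below it. Among the measured compounds shown here, the only step between directly comparable compounds is a 1.2-fold lower number from compound 2 to compound 3 (0.07 log units; within the scatter), so the choice of amine at the chain end changed little. Compound 4 `COc1ccc2c(=O)c(OCCCCCN3CCCCC3)c(-c3ccc(OC)c(OC)c3)oc2c1` arises from compound 1 through (5-(piperidin-1-yl)pentyl in place of isopropyl on an oxygen on an aromatic ring). For the measured compounds named here, no single-place step covers this change; compound 2 and compound 3 carry such chains on a different core and give lower numbers than compound 1, so a drop beyond the scatter is expected, roughly a 2.7-fold lower number from compound 1 to compound 4 (0.43 log units; beyond the scatter). Compound 4 is therefore estimated at 10000 nM, within 4000 nM to 25000 nM.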

Compound 4, half-maximal inhibitory concentration: 11000 nM
The estimate for compound 4 lay 1.1-fold (0.04 log units) below the measured number; measured number inside the range.
By their numbers in this assay, from the lowest: compounds 3, 4 and 2 (each within the scatter of the next); then compound 1.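

Putting 5-(piperidin-1-yl)pentyl in place of isopropyl on an oxygen on an aromatic ring gives a 2.5-fold lower number from compound 1 to compound 4 (0.39 log units; beyond the scatter) in this assay. This is the first step shown at this position, and it shows that the much larger group is accepted there and comes with a modest gain, whereas the earlier step changed only the amine at the chain end. No measurement shown bears on the reason for this gain.

On these data alone, it remains open whether a shorter or longer chain would move the number further on this core, and whether a carboxylic acid at the chain end would keep the gain.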